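Aryl piperazine succinimide amides: taking off the methyl

The compounds below may be only part of what the source reports. "The series", "measured", "known", "first", "only" and "open" are said of these compounds alone.

Measured so far in a functional assay on the whole organism (strain Swiss) with Mus musculus as the target, in the maximal electroshock model, with a stated time of 0.5 h, at a dose of 300 mg/kg by the intraperitoneal route; on this read-out higher numbers stand for a stronger effect at the one dose given and lower numbers for a weaker effect:
- compound 1, `COc1cccc(N2CCN(C(=O)C(C)N3C(=O)CCC3=O)CC2)c1`: 50%
- compound 2, `CC(C(=O)N1CCN(c2ccc(F)cc2)CC1)N1C(=O)CCC1=O`: 50%
- compound 3, `Cc1cccc(N2CCN(C(=O)C(C)N3C(=O)CCC3=O)CC2)c1`: 50%

Compound 3 stands level with compound 1 and compound 2 in this assay. The step of no change at the digits printed from compound 1 to compound 3 (within the scatter), methyl in place of methoxy on an aromatic carbon, stays within the scatter; so does no change at the digits printed from compound 1 to compound 2 (within the scatter) with 4-fluorophenyl in place of 3-methoxyphenyl on the amine nitrogen in the ring, and no change at the digits printed from compound 2 to compound 3 (within the scatter) with 3-methylphenyl in place of 4-fluorophenyl. Across three different aryl groups on that nitrogen the read-out in this assay has not moved beyond the scatter.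

Compound 4, `CC(C(=O)N1CCN(c2ccccc2)CC1)N1C(=O)CCC1=O`, is not yet measured in this assay. It differs from compound 3 by hydrogen in place of methyl on an aromatic carbon; cut one bond further out, the same difference reads 3-methylphenyl to phenyl. All three measured steps are aryl-substituent changes of this kind and none moved the read-out, so no step beyond the scatter is expected here either, and no change at the digits printed from compound 3 to compound 4 (within the scatter) is the estimated step. Compound 4 is therefore expected to give about 50% in this assay, within a range from 30% to 70%, because the steps of no change at the digits printed from compound 1 to compound 3 (within the scatter) and no change at the digits printed from compound 2 to compound 3 (within the scatter) were flat.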

Compound 4, a percentage reported as activity, at one dose (the size of the read-out at that dose, not a potency): 50%
Estimate against measurement, compound 4: no gap at the digits printed, within the range that was stated.
By their numbers in this assay, from the lowest: compounds 1, 2, 3 and 4 (each within the scatter of the next).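

Within the data shown here, with the aromatic ring left without any substituent, hydrogen in place of methyl gives no change at the digits printed from compound 3 to compound 4 (within the scatter) in this assay and supplies the unsubstituted reference that the earlier comparisons lacked. Against that reference, hydrogen in place of fluoro gives no change at the digits printed from compound 2 to compound 4 (within the scatter) and hydrogen in place of methoxy gives no change at the digits printed from compound 1 to compound 4 (within the scatter) so that, among these four compounds, none of the three substituents separates from plain phenyl on this read-out at the one dose given. No supporting measurement is available to explain this flat result.

All four compounds sit at one level at a single dose, so any differences in potency between them remain unresolved, and a dose range would be needed to show them. Also open is whether the flat picture holds for quite different groups on the aromatic ring, such as an amine or a carboxylic acid, or for a longer chain in place of the methyl on the chain carrying the amide carbonyl, which stays constant in all the compounds shown.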